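The source may hold more compounds than are shown below. What is called first, only, known or untested is meant among the compounds shown, and "the series" means these compounds.

Compound 1 `COc1cc(NC(=O)/C=C/c2ccccc2)cc(OC)c1OC`, compound 2 `COc1cc(/C=C/C(=O)Nc2cc(OC)c(OC)c(OC)c2)cc(OC)c1OC` and compound 3 `COc1cc(NC(=O)/C=C/c2cc(OC)c(OC)c(OC)c2)cc(OC)c1` have been measured in a functional assay on HeLa cells (Homo sapiens) for cytotoxicity, read by sulforhodamine B assay, with a stated time of 72 h; on this read-out lower numbers stand for stronger inhibition and higher numbers for weaker inhibition. Compound 1 gives > 50000 nM, a limit of the assay and not a number. Compound 2 gives > 50000 nM, also a limit. Compound 3 gives 38900 nM. Compound 2 and compound 3 differ in one place, (methoxy in place of hydrogen on an aromatic carbon), and that change made a step of an at least 1.2-fold higher number from compound 3 to compound 2 (0.10 log units; that floor lies within the scatter), consistent with the limit of > 50000 nM in this assay, at which 2 of the 3 values shown sit. Compound 4 `COc1ccccc1/C=C/C(=O)Nc1cc(OC)c(OC)c(OC)c1`, still to be measured in this assay, arises from compound 1 by methoxy in place of hydrogen on an aromatic carbon. The difference between the core of compound 1 and the core of compound 3 is not broken down here. The place is not the same: in the measured pair the methoxy enters ortho to two methoxy groups and para to a large group, whereas in compound 4 it enters ortho to a large group, so this is the same kind of change, not the same one. Resting on an at least 1.2-fold higher number from compound 3 to compound 2 (0.10 log units; that floor lies within the scatter), the expected step is a step that the limit leaves unreadable from compound 1 to compound 4. Compound 4 is estimated at 70000 nM, with a range from 25000 nM to 200000 nM.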

Compound 4, half-maximal inhibitory concentration: 6100 nM
Beside the measured number, compound 4's estimate is 11-fold (1.06 log units) above it; measured number outside the range, below it.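

In this assay, methoxy in place of hydrogen on an aromatic carbon, ortho to a large group, gave an at least 8.1-fold lower number from compound 1 to compound 4 (0.91 log units; beyond the scatter). This kind of change therefore does not carry from one core to another in this series with a single size or direction: the same change on two cores in this assay, an at least 1.2-fold higher number (0.10 log units; that floor lies within the scatter) from compound 3 to compound 2 and an at least 8.1-fold lower number (0.91 log units; beyond the scatter) from compound 1 to compound 4, at least 10-fold (1.02 log units) apart, beyond the scatter of two such steps. Going by these compounds, it does not show whether the core or the place of the methoxy sets that gap, as the two pairs differ in both, and the full size of each step stays unknown: the limit of > 50000 nM in this assay, at which 2 of the 4 values shown sit.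

The compounds shown leave open what a hydroxy, an ethoxy or an amine would do on that same aromatic carbon of the core of compound 1. They also leave open whether a methoxy ortho to a large group would act alike on the core of compound 3.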